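Cycloheptyl for 3-Chlorophenyl on a Shared Core

The source may report more compounds than this note shows. Statements on the series, on what has been measured and on what is new or still open speak of the compounds shown alone.

Measured compounds:
compound 1 `Cc1nc2c(cnn2-c2ccccc2)c(=O)n1-c1cccc(Cl)c1` — in an in vitro functional assay on cells for antagonist activity at metabotropic glutamate receptor 1 (Homo sapiens), read by FLIPR and calcium flux (a higher number here means a weaker inhibitor, a lower number a stronger inhibitor), compound 1 gives > 100000 nM
compound 2 `Cc1nc2c(cnn2-c2ccccc2)c(=O)n1-c1ccc(OC(F)(F)F)cc1` — in this assay compound 2 gives > 100000 nM

The value for compound 1 in this assay is a limit of the assay and not a number. The value for compound 2 in this assay is likewise a limit. Both measured compounds therefore sit at the limit of > 100000 nM in this assay, at which 2 of the 2 values shown sit, so compound 1 stands at the edge of what the assay reports and nothing more is known of it than that. Going by the values given here, no step between measured compounds can be computed from two limits.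

Compound 3 `Cc1nc2c(cnn2-c2ccccc2)c(=O)n1C1CCCCCC1` is not yet measured. It differs from compound 1 by cycloheptyl in place of 3-chlorophenyl on an aromatic nitrogen. Since compound 1 offers only a limit, any step from it can only be towards a measurable number or stay at the limit; a move to weaker inhibition would remain hidden. The change is expected to be at most a modest move, more probably towards a measurable inhibitory concentration than away from it.

Compound 3 is estimated to give 30000 nM in this assay, within 2000 nM to 200000 nM, which would mean an expected step of an at least 3.3-fold lower number from compound 1 to compound 3 (0.52 log units; beyond the scatter).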

Compound 3, half-maximal inhibitory concentration: 760 nM
For compound 3 the middle estimate is 39-fold (1.60 log units) above the measured one; measured number outside the range, below it.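

In this assay compound 1 gives > 100000 nM, which is a limit of the assay and not a number. Cycloheptyl in place of 3-chlorophenyl on the aromatic nitrogen gives an at least 130-fold lower number from compound 1 to compound 3 (2.11 log units; beyond the scatter), which shows that the group at this position can bring the shared core from the limit to a measurable inhibitory concentration, and that a non-aromatic ring of carbon only can do so where the 3-chlorophenyl ring did not. The true size of this step remains unknown and only its lower bound can be read, because the starting point is a limit: the limit of > 100000 nM in this assay, at which 2 of the 3 values shown sit.

As far as these compounds go, whether the gain belongs to the seven-membered ring in particular or to saturated carbon rings in general stays open, since a cyclohexyl, a cyclopentyl or an open chain such as n-heptyl on this nitrogen would be needed to separate the two. Also open, from the compounds shown here alone, is how an amine or a hydroxyl on the cycloheptyl ring would read here, and whether the phenyl and methyl groups of the shared core can be changed while this inhibition is kept.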